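From 4-methoxyphenyl to 2-chlorophenyl: a step still unmeasured

A few compounds are considered here, and "the series" means these few. Any claim that something is new, unique, unknown or untested is made for them only; others in the source may bear on it.

Measured so far in a functional assay, read by spectrophotometry, tested at 100 uM; a lower number here means a stronger inhibitor, a higher number a weaker inhibitor:
compound 1 `O=C(/C=C/c1ccc(F)cc1)c1cccc(NC(=O)c2cc(-c3ccncc3)n[nH]2)c1`: 56000 nM
compound 2 `O=C(/C=C/c1ccc(Cl)cc1)c1cccc(NC(=O)c2cc(-c3ccncc3)n[nH]2)c1`: 63900 nM
compound 3 `COc1ccc(/C=C/C(=O)c2cccc(NC(=O)c3cc(-c4ccncc4)n[nH]3)c2)cc1`: 38400 nM

Compound 3 stands level with the other two, since its number lies within the scatter of both. The steps to it are a 1.5-fold lower number from compound 1 to compound 3 (0.16 log units; within the scatter) and a 1.7-fold lower number from compound 2 to compound 3 (0.22 log units; within the scatter).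

Compound 4 `O=C(/C=C/c1ccccc1Cl)c1cccc(NC(=O)c2cc(-c3ccncc3)n[nH]2)c1` has not yet been measured. It carries 2-chlorophenyl in place of 4-methoxyphenyl, on a double-bonded chain carbon bound to a double-bonded chain carbon: 2-chlorophenyl in place of 4-methoxyphenyl on a double-bonded chain carbon bound to a double-bonded chain carbon.

For the measured compounds named here, three measured steps bear on this change. Besides the two above, there is a 1.1-fold higher number from compound 1 to compound 2 (0.06 log units; within the scatter). Each exchanges a single group on an aromatic carbon, and none goes beyond the scatter. Going by the values given here, no measured compound carries the 2-chlorophenyl group, however, so these steps are only indirect guides.

On this evidence, no step beyond the scatter is expected in this assay. The expected step is small, a 1.3-fold higher number from compound 3 to compound 4 (0.11 log units; within the scatter), and its direction is uncertain. The estimate sits among the three measured numbers rather than at any one of them.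

For compound 4 the estimated value is 50000 nM, with an expected range from 25000 nM to 100000 nM.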

Compound 4, half-maximal inhibitory concentration: 27700 nM
The estimate for compound 4 lay 1.8-fold (0.26 log units) above the measured number; the range from low to high includes it.
By their numbers in this assay, from the lowest: compounds 4, 3, 1 and 2 (each within the scatter of the next, the first and the last beyond it).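

In this assay, for the compounds shown here, the 2-chlorophenyl group gives the first steps at this position that pass beyond the scatter: exchanging 4-chlorophenyl for it gives a 2.3-fold lower number from compound 2 to compound 4 (0.36 log units; beyond the scatter) and exchanging 4-fluorophenyl for it gives a 2.0-fold lower number from compound 1 to compound 4 (0.31 log units; beyond the scatter) while every step among the three earlier compounds stayed within the scatter. Compound 4 is not separated from compound 3, however, as the exchange of 4-methoxyphenyl shows with a 1.4-fold lower number from compound 3 to compound 4 (0.14 log units; within the scatter) so this position responds modestly to the change from 4-chlorophenyl to 2-chlorophenyl, but 2-chlorophenyl does not stand apart from all three groups compared here. No measurement shown here offers an explanation for any of these steps.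

The compounds shown leave open whether the modest steps are particular to 2-chlorophenyl or would also appear with another group on the ring, such as an amine or a carboxylic acid. They also leave open how a longer chain in place of the ethenyl link would behave, and whether any such change would give more than a modest step in this assay.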